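This account rests on a few compounds, and the source may have more. Where it says the series, first, only, none or still open, it means among the compounds named here.

For the measured compounds named here, compound 3 `CCCNC(=O)c1ccc(C#Cc2cccc(F)c2)cn1` is one of three compounds measured in a functional assay on HEK293 cells for positive allosteric modulation of metabotropic glutamate receptor 5 (Rattus norvegicus), read by fluorescence and calcium flux; a higher number here means a larger maximal response, a lower number a smaller maximal response. Compound 3 gives 65.9%; compound 2 `Cc1nc(C#Cc2ccc(C(=O)N[C@H](C)C(C)(C)O)nc2)cs1` gives 66.6% and compound 1 `Cc1ccc(C#Cc2ccc(C(=O)N[C@H](C)C(C)(C)O)nc2)cc1` gives 63.1%, so all three values lie within the scatter of one another and none stands apart. Going by the values given here, the only measured step, a number 3.5 percentage points higher from compound 1 to compound 2 (within the scatter), concerns the group on the triple-bonded carbon and leaves the rest of the shared core untouched. Compound 4 `CC1(CCNC(=O)c2ccc(C#Cc3cccc(F)c3)cn2)COC1` differs from compound 3 elsewhere: 3-methyloxetan-3-yl in place of methyl on a saturated chain carbon, two bonds along the chain from an amide-type nitrogen. Among the compounds with values here, no measured step bears on this change, so no shift beyond the scatter is expected in this assay. Compound 4 is estimated to give 65%, between 50% and 80%, which means an expected step of a number 0.9 percentage points lower from compound 3 to compound 4 (within the scatter).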

Compound 4, largest response reached (reported as efficacy), in percent of the reference or control that the assay uses: 65.7%
For compound 4 the middle estimate is 0.7 percentage points below the measured one; measured number inside the range.
By their numbers in this assay, from the lowest: compounds 1, 4, 3 and 2 (each within the scatter of the next).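

In this assay, putting 3-methyloxetan-3-yl in place of methyl on a saturated chain carbon, two bonds along the chain from an amide-type nitrogen, gives a number 0.2 percentage points lower from compound 3 to compound 4 (within the scatter) and so shows that this position accepts a four-membered ring with an oxygen without a shift beyond the scatter. The earlier step concerned only the group on the triple-bonded carbon and could not show this. As far as these compounds go, whether an amine, a carboxylic acid or a longer chain at this place would behave alike stays open. Nothing at hand explains why this change leaves the response within the scatter.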